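The compounds below may be only part of what the source reports. "The series", "measured", "known", "first", "only" and "open" are said of these compounds alone.

Among the measured compounds shown here, compound 2 `Nc1ccc(N2CCN(CCC(=O)c3csc4ccccc34)CC2)cc1` is the only compound here with a number in an assay on HEK293 cells for displacement of a labelled ligand from 5-hydroxytryptamine receptor 7 (Homo sapiens), read by scintillation counting, with a stated time of 1 h (on this read-out higher numbers stand for weaker inhibition and lower numbers for stronger inhibition), giving 14100 nM. Compound 1 `O=C(CCN1CCN(c2ccc([N+](=O)[O-])cc2)CC1)c1csc2ccccc12` carries a nitro group in place of the amino group. In this assay compound 1 reaches only a limit of the assay, > 100000 nM. an at least 7.0-fold lower number from compound 1 to compound 2 (0.85 log units; beyond the scatter); this rests on (the limit of > 100000 nM in this assay, at which 1 of the 2 values shown sits), so the true size of that step is not known. Compound 3 `N#Cc1ccc(N2CCN(CCC(=O)c3csc4ccccc34)CC2)cc1` has not yet been measured. (cyano in place of amino on an aromatic carbon). For the measured compounds named here, of the measured steps only the one from nitro to amino bears on this change, and only loosely, since no measured pair covers cyano at that position. The expectation for compound 3 is therefore a weakening of uncertain size, a 2.8-fold higher number from compound 2 to compound 3 (0.45 log units; beyond the scatter), with a real chance that only a limit is returned. Compound 3 is estimated at 40000 nM, within a range from 12000 nM to 150000 nM.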

Compound 3, inhibition constant: > 100000 nM
Compound 3: a limit, no number; the forecaster's own chance of this, stated with the estimate: 35%; at least 2.5-fold (0.39 log units) between middle value and limit.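

Swapping amino for cyano on the aromatic carbon gives an at least 7.0-fold higher number from compound 2 to compound 3 (0.85 log units; beyond the scatter) in this assay. Amino is now the only one of the three groups shown at this position to give a number, as neither nitro nor cyano gives one, so the measurable binding of compound 2 depends on keeping amino among these groups. Neither the true size of that step nor the step from compound 1 to compound 3 can be read: the limit of > 100000 nM in this assay, at which 2 of the 3 values shown sit.

As far as these compounds go, what remains open is whether amino is unique here or whether a hydroxyl, a methylamino or an acetamide group at the same place would also give a number. The compounds shown also cannot tell whether any group there would bind more strongly than compound 2, at 14100 nM.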